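Swapping the amide nitrogen substituent of a thiophene-methyl amide

A few compounds are considered here, and "the series" means these few. Any claim that something is new, unique, unknown or untested is made for them only; others in the source may bear on it.

Three compounds have been examined in an assay on HEK293 cells for agonist activity at transient receptor potential cation channel subfamily M member 8 (Homo sapiens), read by fluorescence and calcium flux, with a stated time of 15 min; a lower number here means that less compound is needed, a higher number that more compound is needed for the effect. Compound 2 `Cc1ccc(OCC(=O)N(Cc2cccs2)c2ccccn2)cc1` gives 200 nM, the lowest of the two numbers obtained. Compound 3 `CCN(Cc1cccs1)C(=O)COc1ccc2c(c1)CCCC2` gives 689 nM, a gap beyond the usual scatter. Compound 1 `CCN(Cc1cccs1)C(=O)C[C@@H](O)c1ccccc1` is recorded as "not active" (no number reported), without a number. Compound 4 `COCCN(Cc1cccs1)C(=O)COc1ccc(C)cc1` remains to be measured in this assay; it differs from compound 2 in one place: 2-methoxyethyl in place of pyridin-2-yl on an amide-type nitrogen. Going by the values given here, no measured pair shows this exact change, so the step from compound 2 to compound 4 in this assay can only be estimated; the expectation is a loss of potency beyond the scatter, a 6.0-fold higher number from compound 2 to compound 4 (0.78 log units; beyond the scatter). Compound 4 is therefore expected to give about 1200 nM, within a range from 300 nM to 5000 nM.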

Compound 4, half-maximal effective concentration: 400 nM
Compound 4: middle estimate off by 3.0-fold (0.48 log units), on the high side; low and high end bracket the measured number.
By their numbers in this assay, from the lowest: compounds 2, 4 and 3 (each within the scatter of the next, the first and the last beyond it).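

In this assay, 2-methoxyethyl in place of pyridin-2-yl on the amide-type nitrogen gives a 2.0-fold higher number from compound 2 to compound 4 (0.30 log units; within the scatter). For this pair, then, the six-membered aromatic ring at this nitrogen can be exchanged for a chain with no ring without a step beyond the scatter. Nothing measured here accounts for this result. Left open is whether a plain butyl chain, or a chain ending in an amine or a carboxylic acid, would read the same at this nitrogen. Also open, going by these compounds, is how a phenyl ring would compare there.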